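Amine tail exchange and cell tolerance: notes toward compound 4

This account rests on a few compounds, and the source may have more. Where it says the series, first, only, none or still open, it means among the compounds named here.

Compound 1 `CN1CCN(CCCNCc2cn(-c3ccc(C(F)(F)F)cc3)nc2-c2ccc(Cl)cc2)CC1` is the reference of the set. In an ADME assay on Huh-7 cells (Homo sapiens) for cytotoxicity (a higher number here means that more compound is tolerated, a lower number that less compound is tolerated), compound 1 gives 2500 nM. Compound 2 `CCCN1CCC(CNCc2cn(-c3ccc(C(F)(F)F)cc3)nc2-c2ccc(Cl)cc2)CC1` carries 1-propylpiperidin-4-yl in place of 2-(4-methylpiperazin-1-yl)ethyl on a saturated chain carbon bound to an amine nitrogen and in this assay compound 2 gives 1900 nM; the step is a 1.3-fold lower number from compound 1 to compound 2 (0.12 log units; within the scatter). Compound 3 `CN1CCN(CCCNCc2cn(-c3ccc(C(F)(F)F)cc3)nc2-c2ccc(OC(F)(F)F)cc2)CC1` differs from compound 1 by trifluoromethoxy in place of chloro on an aromatic carbon; in this assay compound 3 gives 2300 nM, a step of a 1.1-fold lower number from compound 1 to compound 3 (0.04 log units; within the scatter). Going by the values given here, no counted step joins compound 2 and compound 3; their two numbers simply stand close to each other.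

Compound 4 `CCCN1CCC(CNCc2cn(-c3ccc(C(F)(F)F)cc3)nc2-c2ccc(OC(F)(F)F)cc2)CC1` is the partner of compound 3 carrying (1-propylpiperidin-4-yl in place of 2-(4-methylpiperazin-1-yl)ethyl on a saturated chain carbon bound to an amine nitrogen). This is the same change as from compound 1 to compound 2, at the same place, and the two cores differ only in the way told by trifluoromethoxy in place of chloro on an aromatic carbon. The step expected here is a 1.3-fold lower number from compound 3 to compound 4 (0.11 log units; within the scatter), resting on the measured 1.3-fold lower number from compound 1 to compound 2 (0.12 log units; within the scatter), which lay within the scatter. The estimate for compound 4 in this assay is accordingly 1800 nM, with a range from 1000 nM to 3200 nM.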

Compound 4, half-maximal cytotoxic concentration: 2200 nM
The estimate for compound 4 lay 1.2-fold (0.09 log units) below the measured number, and the stated range covers the measured number.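

In this assay the exchange of 2-(4-methylpiperazin-1-yl)ethyl for 1-propylpiperidin-4-yl gives a 1.0-fold lower number from compound 3 to compound 4 (0.02 log units; within the scatter), and this stands beside the earlier step on the core of compound 1: the same change on two cores in this assay, a 1.3-fold lower number (0.12 log units; within the scatter) from compound 1 to compound 2 and a 1.0-fold lower number (0.02 log units; within the scatter) from compound 3 to compound 4, 1.3-fold (0.10 log units) apart, within the scatter of two such steps

The exchange of chloro for trifluoromethoxy gives a 1.2-fold higher number from compound 2 to compound 4 (0.06 log units; within the scatter), and this too matches its earlier counterpart: the same change on two cores in this assay, a 1.1-fold lower number (0.04 log units; within the scatter) from compound 1 to compound 3 and a 1.2-fold higher number (0.06 log units; within the scatter) from compound 2 to compound 4, 1.3-fold (0.10 log units) apart, within the scatter of two such steps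

Each change therefore carries from one core to the other without a gap beyond the scatter, but every step among these compounds also lies within the scatter, so this agreement shows only that neither change produced a step that can be told from the scatter on either core, not that a clear effect transfers reliably between cores.

Open, as far as these compounds go, is whether a tail ending in a morpholine or a primary amine would stay equally close to these numbers. Also open, from the compounds shown here alone, is whether a nitrile or a carboxylic acid in place of chloro on the aromatic carbon would do the same.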